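Working notes: from compound 3 to compound 4

The source may report more compounds than this note shows. Statements on the series, on what has been measured and on what is new or still open speak of the compounds shown alone.

In a functional assay on SMMC-7721 cells (Homo sapiens) for antiproliferative activity, read by MTT assay, with a stated time of 48 h (on this read-out higher numbers stand for weaker inhibition and lower numbers for stronger inhibition), the measured compounds read as follows:
- compound 1 `CC(C)=CCC[C@]1(C)/C=C/[C@@H](OC(=O)C=C(C)C)[C@](C)(O)/C=C/C(=O)/C(CN2CCN(C)CC2)=C\C1` gives 2940 nM
- compound 2 `CC[Si](CC)(CC)C/C1=C/C[C@](C)(CCC=C(C)C)/C=C/[C@@H](OC(=O)C=C(C)C)[C@](C)(O)/C=C/C1=O` gives 3460 nM
- compound 3 `COCOC/C1=C/C[C@](C)(CCC=C(C)C)/C=C/[C@@H](OC(=O)C=C(C)C)[C@](C)(O)/C=C/C1=O` gives 3250 nM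

Compound 3 stands level with the other two, within the scatter of both. Compound 4 `CSC(=S)OC/C1=C/C[C@](C)(CCC=C(C)C)/C=C/[C@@H](OC(=O)C=C(C)C)[C@](C)(O)/C=C/C1=O` differs from it by a group of 4 heavy atoms (2 carbon, 2 sulfur; no ring) in place of a group of 3 heavy atoms (2 carbon, 1 oxygen; no ring), on an oxygen on a saturated carbon on an oxygen on a saturated carbon. For the measured compounds named here, no measured step covers this exact change. The nearest evidence is three exchanges on a saturated chain carbon bound to a double-bonded ring carbon: a 1.1-fold higher number from compound 1 to compound 3 (0.04 log units; within the scatter) and a 1.1-fold lower number from compound 2 to compound 3 (0.03 log units; within the scatter) and a 1.2-fold higher number from compound 1 to compound 2 (0.07 log units; within the scatter) with each within the scatter. No step beyond the scatter is therefore expected in this assay and no direction can be favoured. The expected size is a 1.0-fold lower number from compound 3 to compound 4 (0.01 log units; within the scatter) at most a small shift. For compound 4 the estimate is 3200 nM with an expected range from 1600 nM to 6500 nM in this series.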

Compound 4, half-maximal inhibitory concentration: 720 nM
The estimate for compound 4 lay 4.4-fold (0.65 log units) above the measured number; measured number outside the range, below it.
By their numbers in this assay, from the lowest: compound 4; then compounds 1, 3 and 2 (each within the scatter of the next).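

In this assay the oxygen on a saturated carbon proves able to carry a change beyond the scatter: a 4.5-fold lower number from compound 3 to compound 4 (0.65 log units; beyond the scatter) and a 4.8-fold lower number from compound 2 to compound 4 (0.68 log units; beyond the scatter) and a 4.1-fold lower number from compound 1 to compound 4 (0.61 log units; beyond the scatter) while compounds 1, 2 and 3 stay within the scatter of one another. The three earlier groups therefore did not show that this part of the molecule is insensitive to every exchange. No measurement at hand bears on the reason for this step.

Which part of the entering group carries the step stays open. Also open, going by these compounds, is whether a longer chain in place of its methyl, or an amine in place of that group, keeps the lower number.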